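Fluoro to methyl on the triazolylmethyl amide of compound 3

This account rests on a few compounds, and the source may have more. Where it says the series, first, only, none or still open, it means among the compounds named here.

Compound 1, `CC(C)n1ncc2c(C(=O)Nc3ccccc3)cccc21`: 19700 nM
Compound 2, `CC(C)n1ncc2c(C(=O)NC3CCCC3)cccc21`: > 40000 nM
Compound 3, `CC(C)n1ncc2c(C(=O)NCc3cn(-c4ccc(F)cc4)nn3)cccc21`: > 40000 nM

Three amides built on one shared core have been tested in a functional assay on MCF7 cells (Homo sapiens) for inhibition, read by MTT assay, with a stated time of 72 h; a lower number here means a stronger inhibitor, a higher number a weaker inhibitor. Within the data shown here, compound 1 is the only one that returns a number, 19700 nM. Among the measured compounds shown here, for compound 2 the assay gives only a limit, > 40000 nM, and the single measured step, an at least 2.0-fold higher number from compound 1 to compound 2 (0.30 log units; that floor lies within the scatter), is therefore a floor rather than a size. On these data alone, for compound 3 the assay again reports only a limit, > 40000 nM, so compound 3 stands at the limit of > 40000 nM in this assay, at which 2 of the 3 values shown sit, and its true value is unknown beyond that.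

Compound 4, `Cc1ccc(-n2cc(CNC(=O)c3cccc4c3cnn4C(C)C)nn2)cc1`, differs from compound 3 by methyl in place of fluoro on an aromatic carbon. No measured step touches this ring; the only measured step changes the group on the amide nitrogen, so nothing shown bears directly on an exchange of fluoro for methyl. In this assay no step beyond the scatter is expected, and compound 4 is estimated at 45000 nM, within 20000 nM to 100000 nM, which means an expected step that the limit leaves unreadable from compound 3 to compound 4.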

Compound 4, half-maximal inhibitory concentration: > 40000 nM
Compound 4: a limit, no number; the forecaster's own chance of this, stated with the estimate: 70%; the middle value does not contradict the limit.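

Compound 4 returns only a limit in this assay, > 40000 nM. Compound 3 is also a limit, so no step can be read between compound 3 and compound 4. The compounds shown leave open how 4-fluorophenyl and 4-methylphenyl compare in this assay.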